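Cyano Enters the Phenyl Ring of Compound 2

This account rests on a few compounds, and the source may have more. Where it says the series, first, only, none or still open, it means among the compounds named here.

Compound 1 `Nc1ccccc1NC(=O)c1ccc(CSC(=S)N2CCN(C(c3ccccc3)c3ccccc3)CC2)cc1`: 8.7%
Compound 2 `Nc1ccccc1NC(=O)c1ccc(CSC(=S)N2CCN(c3ccccc3)CC2)cc1`: 27.5%

Both measured compounds were tested in a functional assay on A-375 cells (Homo sapiens) for antiproliferative activity, read by CCK-8 assay, with a stated time of 72 h, tested at 2 uM; a lower number here means a weaker effect, a higher number a stronger effect of the compound at the concentration tested. Compound 1 gives 8.7% there, while compound 2 gives 27.5%, the higher of the two numbers; the gap between them lies beyond the usual scatter of repeated measurements of this kind. Compound 3 `N#Cc1ccc(N2CCN(C(=S)SCc3ccc(C(=O)Nc4ccccc4N)cc3)CC2)cc1` has not yet been measured. It differs from compound 2 in a single place: cyano in place of hydrogen on an aromatic carbon. Among the measured compounds shown here, no step between measured compounds shows how such a change plays out, so the expectation rests on compound 2 alone. The change is small, and the read-out in this assay is expected to stay close to where compound 2 stands, perhaps rising a little; the step this expectation means is a number 4.5 percentage points higher from compound 2 to compound 3 (within the scatter), which may not exceed the scatter. Compound 3 is therefore expected to give about 32%, within a range from 14% to 52%.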

Compound 3, a percentage reported as inhibition, at one concentration (the size of the read-out at that concentration, not a potency): 41.4%
Estimate against measurement, compound 3: 9.4 percentage points below; low and high end bracket the measured number.
By their numbers in this assay, from the lowest: compound 1; then compound 2; then compound 3.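

At this position, a carbon of the phenyl ring para to a large group, the change from phenyl to 4-cyanophenyl gives a number 13.9 percentage points higher from compound 2 to compound 3 (beyond the scatter) in this assay. Among the compounds shown here, this is the first measured step at this place, and it shows that the position accepts a cyano group and that the read-out can move upward beyond the usual scatter when it does. No measurement shown here gives a reason for the rise.

With only one substituent at this place, the compounds shown cannot say whether the rise is particular to cyano or would also appear with another group, such as an amine, a carboxylic acid or a longer chain. They also leave open whether compound 3 would keep its effect with the cyano group at another carbon of the same ring.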